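The source may hold more compounds than are shown below. What is called first, only, known or untested is meant among the compounds shown, and "the series" means these compounds.

The measured compounds are:
Compound 1, `O=C(C1CCN(c2ccncn2)CC1)N1N=CC[C@H]1c1ccccc1`, gives 3.3 h in an ADME assay on cells (Hepatocyte, Homo sapiens) for metabolic stability; a lower number here means that the compound disappears faster, a higher number that the compound lasts longer.
Compound 2, `CC(=O)N1CCC(C(=O)N2N=CC[C@H]2c2ccccc2)CC1`, reaches only a limit of the assay, > 3.11 h, in this assay.
Compound 3, `CC1=NN(C(=O)C(C)(C)C)[C@H](c2ccccc2)C1`, gives 0.617 h in this assay.

Compound 2 therefore stands at the upper edge of what this assay reports, where (the limit of > 3.11 h in this assay, at which 1 of the 3 values shown sits); its number is not known, and the step that the limit leaves unreadable from compound 1 to compound 2 cannot be read in size or direction. Compound 4, `O=C(C1CCN(c2ncccn2)CC1)N1N=CC[C@H]1c1ccccc1`, differs from compound 2 in one place: pyrimidin-2-yl in place of acetyl on an amine nitrogen in a ring. Among the measured compounds shown here, the only measured step that touches this position is the one from compound 1 to compound 2, and the limit leaves it without a size, so no size of step in this assay can be taken from it. What the numbers do show is that compound 1, which also carries a six-membered aromatic ring with two hetero atoms on the amine nitrogen in the ring, gives 3.3 h. That value lies close to where compound 2 sits. Compound 4 is accordingly expected in that same region, with the step that the limit leaves unreadable from compound 2 to compound 4 expected to stay within the scatter. Compound 4 is estimated at 3.2 h, between 1.7 h and 6 h.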

Compound 4, half-life: > 3.11 h
Compound 4: only a limit was reported; the forecaster's own chance of this, stated with the estimate: 40%; the middle value is on the limit's open side.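

In this assay, among the compounds shown here, compound 4 reaches only a limit of > 3.11 h and no step linking it to compound 1 or compound 2 can be read: the limit of > 3.11 h in this assay, at which 2 of the 4 values shown sit. The compounds shown leave open how long compound 2 and compound 4 actually last, and whether acetyl, pyrimidin-2-yl or pyrimidin-4-yl on the amine nitrogen in the ring changes that.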